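The compounds below may be only part of what the source reports. "The series", "measured", "known", "first", "only" and "open" are said of these compounds alone.

In a functional assay (aorta) with Rattus norvegicus as the target (a higher number here means a weaker inhibitor, a lower number a stronger inhibitor), the measured compounds are these.
Compound 1 `CCNC(=O)CN(c1ccccc1)[C@H]1c2cc(C#N)ccc2OC(C)(C)[C@@H]1O` reaches only a limit, > 30000 nM.
Compound 2 `CC1(C)Oc2ccc(C#N)cc2[C@H](N(CC#N)c2ccccc2)[C@H]1O` gives 59000 nM.
Compound 3 `CCOC(=O)NN(c1ccccc1)[C@H]1c2cc(C#N)ccc2OC(C)(C)[C@@H]1O` gives 2200 nM.

Compound 3 holds the lowest of the two real numbers: the nearest sits a 27-fold lower number from compound 2 to compound 3 (1.43 log units; beyond the scatter), and from the limit side there is an at least 13-fold lower number from compound 1 to compound 3 (1.13 log units; beyond the scatter). The comparison of compound 1 with compound 2 cannot be read because the limit of > 30000 nM in this assay, at which 1 of the 3 values shown sits, hides its size.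

Compound 4 `Cc1cc(CN(c2ccccc2)[C@H]2c3cc(C#N)ccc3OC(C)(C)[C@@H]2O)on1` has not been measured; it differs from compound 3 by (3-methyl-1,2-oxazol-5-yl)methyl in place of (ethoxycarbonyl)amino on a nitrogen on an aromatic ring. Within the data shown here, no measured step swaps in exactly this group. The two steps that bear on it, an at least 13-fold lower number from compound 1 to compound 3 (1.13 log units; beyond the scatter) and a 27-fold lower number from compound 2 to compound 3 (1.43 log units; beyond the scatter), both put the (ethoxycarbonyl)amino group in place of a group whose name ends in methyl, and both were large falls. Compound 4 returns to a group of that kind, so the expected move is a large rise, a 9.1-fold higher number from compound 3 to compound 4 (0.96 log units; beyond the scatter). Compound 4 is estimated at 20000 nM, in the range 4000 nM to 80000 nM, with a real chance that only a limit is reported.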

Compound 4, half-maximal inhibitory concentration: > 30000 nM
Compound 4 was reported as a limit (the forecaster's own chance of this, stated with the estimate: 35%); middle value at least 1.5-fold (0.17 log units) away from the limit.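

In this assay, compound 4 reaches only a limit, > 30000 nM. On this nitrogen, putting (3-methyl-1,2-oxazol-5-yl)methyl in place of (ethoxycarbonyl)amino gives an at least 13-fold higher number from compound 3 to compound 4 (1.13 log units; beyond the scatter), so the large loss seen with the two chain groups also appears with a group carrying a five-membered aromatic ring. The steps from compound 1 and from compound 2 to compound 4 cannot be read because of the limit: the limit of > 30000 nM in this assay, at which 2 of the 4 values shown sit.

Compound 3 is the only compound shown whose group is joined to this nitrogen through another nitrogen, so the link and the ethoxycarbonyl part cannot be told apart. A plain amino group or an acetylamino group in the same place would bear on that question.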